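Replacing Phenylsulfanyl with Benzyl on the Shared Core

A few compounds are considered here, and "the series" means these few. Any claim that something is new, unique, unknown or untested is made for them only; others in the source may bear on it.

- compound 1 `CC(C)(C)c1ccc(OC(C)(C)C2OCC(C/C=C\CCC(=O)O)C(c3cccnc3)O2)cc1`: 1910 nM
- compound 2 `COc1ccccc1OC(C)(C)C1OCC(C/C=C\CCC(=O)O)C(c2cccnc2)O1`: 224 nM
- compound 3 `CC(C)(Sc1ccccc1)C1OCC(C/C=C\CCC(=O)O)C(c2cccnc2)O1`: 200 nM

In a functional assay for inhibition, with Homo sapiens as the target (a lower number here means tighter binding, a higher number weaker binding), compound 3 cannot be told apart from compound 2, and compound 1 stands clearly higher than both. Compound 4 `CC(C)(Cc1ccccc1)C1OCC(C/C=C\CCC(=O)O)C(c2cccnc2)O1` is still unmeasured. It carries benzyl in place of phenylsulfanyl on a saturated chain carbon bound to two saturated chain carbons and a saturated ring carbon. For the measured compounds named here, no measured step makes this exchange. At the same place, the swap of 2-methoxyphenoxy for phenylsulfanyl gave a 1.1-fold lower number from compound 2 to compound 3 (0.05 log units; within the scatter), while the larger steps of an 8.5-fold lower number from compound 1 to compound 2 (0.93 log units; beyond the scatter) and a 9.6-fold lower number from compound 1 to compound 3 (0.98 log units; beyond the scatter) both start from the 4-(tert-butyl)phenoxy group, which is absent here. No change beyond the scatter is therefore expected, and the estimated step is a 1.2-fold higher number from compound 3 to compound 4 (0.08 log units; within the scatter). Compound 4 is expected at 240 nM, with an estimated range from 90 nM to 650 nM.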

Compound 4, dissociation constant: 513 nM
Compound 4: middle estimate off by 2.1-fold (0.33 log units), on the low side, and the stated range covers the measured number.
By their numbers in this assay, from the lowest: compounds 3 and 2 (each within the scatter of the next); then compound 4; then compound 1.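

In this assay, the exchange gave a 2.6-fold higher number from compound 3 to compound 4 (0.41 log units; beyond the scatter) although phenylsulfanyl and benzyl have the same heavy-atom count and the same aromatic ring, so this place distinguishes between groups that match on those counts. Benzyl also gave a 2.3-fold higher number from compound 2 to compound 4 (0.36 log units; beyond the scatter) from the 2-methoxyphenoxy compound, yet a 3.7-fold lower number from compound 1 to compound 4 (0.57 log units; beyond the scatter) shows it remains preferable to 4-(tert-butyl)phenoxy. No measurement on hand accounts for these differences. On these data alone, it remains open whether an unsubstituted phenoxy group or an amine-linked phenyl group at this place would track compound 3 or compound 4.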